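This account rests on a few compounds, and the source may have more. Where it says the series, first, only, none or still open, it means among the compounds named here.

Measured compounds:
- compound 1, `N#Cc1ccc(C2OCC(C/C=C\CCC(=O)O)C(c3cccnc3)O2)cc1`, with 1290 nM
- compound 2, `N#Cc1ccccc1C1OCC(C/C=C\CCC(=O)O)C(c2cccnc2)O1`, with 245 nM
- compound 3, `O=C(O)CC/C=C\CC1COC(c2ccc(Cl)cc2Cl)OC1c1cccnc1`, with 891 nM

All three were tested in a functional assay for inhibition, with Homo sapiens as the target; on this read-out lower numbers stand for tighter binding and higher numbers for weaker binding. Compound 3 stands second highest of the three numbers: its nearest neighbour is compound 1, and the two are within the scatter of each other, while compound 2 sits clearly apart, as a 3.6-fold higher number from compound 2 to compound 3 (0.56 log units; beyond the scatter) shows.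

Compound 4, `O=C(O)CC/C=C\CC1COC(c2ccsc2)OC1c1cccnc1`, has not yet been measured. It differs from compound 3 in one place: thiophen-3-yl in place of 2,4-dichlorophenyl on a saturated ring carbon. Every measured step concerns this same position. The swap of a 5.3-fold lower number from compound 1 to compound 2 (0.72 log units; beyond the scatter) was modest, and a 1.4-fold lower number from compound 1 to compound 3 (0.16 log units; within the scatter) stayed within the scatter, so swaps of the aromatic group here have so far moved the number at most modestly. Within the data shown here, no measured step involves thiophen-3-yl, so the direction cannot be read from the three compounds. Compound 4 is therefore expected to land near compound 3, with a 1.1-fold lower number from compound 3 to compound 4 (0.05 log units; within the scatter) as the expected step. The estimate for compound 4 is 800 nM, within a range from 250 nM to 2500 nM.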

Compound 4, dissociation constant: 1580 nM
Beside the measured number, compound 4's estimate is 2.0-fold (0.30 log units) below it; low and high end bracket the measured number.
By their numbers in this assay, from the lowest: compound 2; then compounds 3, 1 and 4 (each within the scatter of the next).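

In this assay, a five-membered sulfur-containing aromatic ring can replace a six-membered carbon ring on this saturated ring carbon without a change beyond the scatter: a 1.8-fold higher number from compound 3 to compound 4 (0.25 log units; within the scatter) and a 1.2-fold higher number from compound 1 to compound 4 (0.09 log units; within the scatter) both stay within it. The new result also sets 2-cyanophenyl further apart, with a 6.4-fold higher number from compound 2 to compound 4 (0.81 log units; beyond the scatter), so compound 2 now lies beyond the scatter from all three other compounds, while compounds 1, 3 and 4 form a group despite their different aromatic rings. Nothing available explains why these groups give these numbers.

The compounds shown leave open whether a plain phenyl ring or a 2-methoxyphenyl group at this carbon would fall with compound 2 or with the other three. They also leave open whether the same pattern would hold with a pyridin-4-yl group in place of the pyridin-3-yl group.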